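The source may hold more compounds than are shown below. What is called first, only, known or untested is meant among the compounds shown, and "the series" means these compounds.

Measured in a functional assay on SMMC-7721 cells (Homo sapiens) for inhibition, read by CCK-8 assay, with a stated time of 72 h, tested at 8 uM; a lower number here means less inhibition of growth, a higher number more inhibition of growth at the concentration tested:
- compound 1 `Cc1cc(C)cc(SCc2ccc(/C=C/C(=O)Nc3ccccc3N)cc2)c1`: 7.13%
- compound 2 `Nc1ccccc1NC(=O)c1ccc(CSc2cccc(F)c2)cc1`: 83%

Compound 1 at 7.13% is the lower of the two numbers. Compound 2 at 83% lies far above it, well beyond the usual scatter.

Not yet measured is compound 3 `Cc1ccc(SCc2ccc(/C=C/C(=O)Nc3ccccc3N)cc2)cc1`. It carries 4-methylphenyl in place of 3,5-dimethylphenyl on a sulfur whose other neighbour is a saturated chain carbon: 4-methylphenyl in place of 3,5-dimethylphenyl on a sulfur.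

For the measured compounds named here, no measured pair shows this change, so the data give no step size for it. The starting point is compound 1 at 7.13%, low on the scale, so any sizeable move in this assay is expected to be upward. The expected outcome is a modest rise, possibly not beyond the scatter, shown as a number 6.9 percentage points higher from compound 1 to compound 3 (within the scatter). For compound 3 the estimated value is 14%, with an expected range from 2% to 38%.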

Compound 3, percent growth inhibition at one concentration: 22.2%
Beside the measured number, compound 3's estimate is 8.2 percentage points below it; low and high end bracket the measured number.
By their numbers in this assay, from the lowest: compound 1; then compound 3; then compound 2.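

In this assay, the group on the sulfur turns out to matter within this series: 4-methylphenyl in place of 3,5-dimethylphenyl gives a number 15.1 percentage points higher from compound 1 to compound 3 (beyond the scatter) with the rest of the structure unchanged. The step is modest, and compound 3 at 22.2% still sits low on the scale, so this change alone does not bring strong growth inhibition at the concentration tested. No measurement available here accounts for the step.

The swap removes one methyl and also changes where the methyl groups sit, so the two changes cannot be separated on this single pair. Plain phenyl would help to separate them, while 4-methoxyphenyl or 4-aminophenyl on the same sulfur would show whether this position tolerates anything other than methyl-bearing rings.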